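Two compounds and a naphthyl swap on the shared core

A few compounds are considered here, and "the series" means these few. Any claim that something is new, unique, unknown or untested is made for them only; others in the source may bear on it.

Of the compounds shown here, two of a shared core have been tested in a functional assay on OVCAR-5 cells (Homo sapiens) for inhibition, read by sulforhodamine B assay, with a stated time of 48 h, tested at 10 uM; a lower number here means less inhibition, a higher number more inhibition at the concentration tested (going by the name of the read-out). Compound 1 `Clc1ccc(-c2cn3ccnc3c(-c3ccc4ncn(C5CCCCC5)c4c3)n2)cc1` gives 0.84% in this assay, and compound 2 `CCc1ccc(-c2cn3ccnc3c(-c3ccc4ncn(Cc5ccccc5)c4c3)n2)cc1` gives 14.9%, the higher of the two numbers, beyond the scatter from compound 1. Compound 3 `c1ccc(Cn2cnc3ccc(-c4nc(-c5cccc6ccccc56)cn5ccnc45)cc32)cc1` has not yet been measured. It differs from compound 2 in one place: naphthalen-1-yl in place of 4-ethylphenyl on an aromatic carbon. Among the measured compounds shown here, no measured pair shows this kind of change, so little guides the expectation. The expected step of a number 0.1 percentage points higher from compound 2 to compound 3 (within the scatter) is none beyond the scatter. Compound 3 is therefore estimated at 15%, with a range from 0% to 40%.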

Compound 3, a percentage reported as inhibition, at one concentration (the size of the read-out at that concentration, not a potency): 1.83%
Compound 3: middle estimate off by 13.2 percentage points, on the high side; low and high end bracket the measured number.
By their numbers in this assay, from the lowest: compounds 1 and 3 (each within the scatter of the next); then compound 2.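

Putting naphthalen-1-yl in place of 4-ethylphenyl on this aromatic carbon of the shared core gives a number 13.1 percentage points lower from compound 2 to compound 3 (beyond the scatter) in this assay. Among the compounds shown here, this is the first single-place comparison, and it shows that inhibition at the tested concentration depends on the group held at this position, though one pair sets no general trend. Nothing measured here explains the change. The compounds shown leave open how 4-aminophenyl or 4-methoxyphenyl would behave at this position. They also leave open whether naphthalen-2-yl would match naphthalen-1-yl.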